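The compounds below may be only part of what the source reports. "The series", "measured", "known", "first", "only" and "open" are said of these compounds alone.

Measured so far:
compound 1 `COc1cc(CNC(=O)/C=C/c2cccc(O)c2)ccc1OCc1nc(C)c(C)nc1C` — 3680 nM
compound 2 `COc1cc(CNC(=O)/C=C/c2cccc(OCc3nc(C)c(C)nc3C)c2)ccc1OCc1nc(C)c(C)nc1C` — 8700 nM

Both numbers come from a functional assay on SH-SY5Y cells (Homo sapiens) for cytotoxicity, read by MTT assay, with stated times of 24 h and 4 h; on this read-out higher numbers stand for an effect only at larger amounts of compound and lower numbers for an effect already at smaller amounts. Among the measured compounds shown here, compound 2 stands highest of the two numbers measured; its nearest neighbour is compound 1, and the single step between them, a 2.4-fold higher number from compound 1 to compound 2 (0.37 log units; beyond the scatter), lies beyond the scatter. Compound 3 `COc1cc(CNC(=O)/C=C/c2ccc(OC)c(OCc3nc(C)c(C)nc3C)c2)ccc1OCc1nc(C)c(C)nc1C` is not yet measured in this assay. It differs from compound 2 by methoxy in place of hydrogen on an aromatic carbon. For the measured compounds named here, no measured step exchanges a ring hydrogen for a methoxy group; the only step at hand, a 2.4-fold higher number from compound 1 to compound 2 (0.37 log units; beyond the scatter), concerns a different and much larger group placed on an oxygen, so it bears on the new step only loosely. Going by the values given here, with no precedent for the methoxy change, a step within the usual scatter in this assay is expected, if anything a slight rise in the number. The step expected here is a 1.1-fold higher number from compound 2 to compound 3 (0.04 log units; within the scatter). For compound 3 the estimate is 9500 nM, with a range from 4500 nM to 20000 nM.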

Compound 3, half-maximal effective concentration: 11600 nM
Compound 3: middle estimate off by 1.2-fold (0.09 log units), on the low side; measured number inside the range.
By their numbers in this assay, from the lowest: compound 1; then compounds 2 and 3 (each within the scatter of the next).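

In this assay, methoxy in place of hydrogen on the aromatic carbon ortho to a (3,5,6-trimethylpyrazin-2-yl)methoxy group and para to a large group gives a 1.3-fold higher number from compound 2 to compound 3 (0.12 log units; within the scatter) and so leaves the read-out within the scatter. Among the compounds shown here, this is the only step at hand on an aromatic carbon, whereas the earlier one, a 2.4-fold higher number from compound 1 to compound 2 (0.37 log units; beyond the scatter) on the same read-out, placed its group on an oxygen and lies beyond the scatter. No measured property bears on this result.

From the compounds shown here alone, whether an amine, a carboxylic acid or a longer chain such as ethoxy at this position would also stay within the scatter remains open. Also open, going by these compounds, is whether methoxy at this position would give a similar step on compound 1, which carries hydrogen on the neighbouring oxygen.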